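The compounds below may be only part of what the source reports. "The series", "measured", "known", "first", "only" and "open" are said of these compounds alone.

The measured compounds, each tested in a functional assay (aorta) with Rattus norvegicus as the target; on this read-out lower numbers stand for an effect already at smaller amounts and higher numbers for an effect only at larger amounts of compound:

Compound 1, `Cc1ccc(NC(=O)NC2CC(C)(C)Oc3ccc(F)cc32)cc1`, gives > 30000 nM, which is a limit of the assay and not a number.
Compound 2, `Cc1ccc(NC(=O)NC2CC(C)(C)Oc3ccc(Cl)cc32)cc1`, gives > 30000 nM, likewise a limit of the assay.
Compound 3, `CC1(C)CC(NC(=O)Nc2cccc(Cl)c2)c2cc(F)ccc2O1`, gives > 300000 nM, again a limit of the assay rather than a number.

Compound 2 differs from compound 1 by chloro in place of fluoro on an aromatic carbon. The step that the two limits leave unreadable from compound 1 to compound 2 cannot be sized, because both values sit at the limit of > 30000 nM in this assay, at which 2 of the 3 values shown sit. Compound 3 differs from compound 1 in its core by 3-chlorophenyl in place of 4-methylphenyl on an amide-type nitrogen, and the step that the two limits leave unreadable from compound 1 to compound 3 is equally unreadable, because compound 1 sits at the limit of > 30000 nM in this assay, at which 2 of the 3 values shown sit, while compound 3 sits at the limit of > 300000 nM in this assay, at which 1 of the 3 values shown sits.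

Compound 4, `CC1(C)CC(NC(=O)Nc2cccc(Cl)c2)c2cc(Cl)ccc2O1`, has not yet been measured in this assay. Among the compounds with values here, it differs from compound 3 by chloro in place of fluoro on an aromatic carbon, which is the same change as the one from compound 1 to compound 2, made at the same place on the shared core. That earlier change left no readable step, and compound 3 itself sits at the limit of > 300000 nM in this assay, at which 1 of the 3 values shown sits, so compound 4 is expected to remain without a measurable effect; the step from compound 3 is estimated as a step that the limit leaves unreadable from compound 3 to compound 4. Compound 4 is therefore estimated at 400000 nM in this assay, with the expected range running from 100000 nM to 1500000 nM, and most likely the assay will again report only a limit.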

Compound 4, half-maximal effective concentration: > 30000 nM
Compound 4: only a limit was reported; the forecaster's own chance of this, stated with the estimate: 90%; the middle value does not contradict the limit.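

In this assay, compound 4 also gives only a limit of the assay and not a number, so neither its step from compound 3 nor its step from compound 2 can be read. The compounds shown leave open whether chloro in place of fluoro on an aromatic carbon, or 3-chlorophenyl in place of 4-methylphenyl on an amide-type nitrogen, changes the effect at all.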